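Removing the piperazinyl group: solubility of compound 3 at low pH

This account rests on a few compounds, and the source may have more. Where it says the series, first, only, none or still open, it means among the compounds named here.

Measured compounds:
compound 1 `CNc1nc(NCCCN(C)C)c2sc(-c3ccc(OC)nc3)cc2n1` with > 100 ug/mL
compound 2 `CNc1nc(NCCCN(C)C)c2sc(-c3ccc(N4CCNCC4)cc3)cc2n1` with > 100 ug/mL

In a physicochemical assay for solubility, at pH 2 (a lower number here means a less soluble compound, a higher number a more soluble compound), compound 1 gives > 100 ug/mL, which is a limit of the assay and not a number. In this assay compound 2 likewise gives > 100 ug/mL, again a limit. Both values therefore rest at the same point, (the limit of > 100 ug/mL in this assay, at which 2 of the 2 values shown sit), so nothing can be said of an order between compound 1 and compound 2.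

Compound 3 `CNc1nc(NCCCN(C)C)c2sc(-c3ccccc3)cc2n1` has not yet been measured. It differs from compound 2 in one place: hydrogen in place of piperazin-1-yl on an aromatic carbon. The shared core and the dimethylaminopropyl chain remain unchanged.

Going by the values given here, since no step between measured compounds has been seen, the expected direction rests only on the structural change and on the limit of compound 2. Compound 3 is expected to be less soluble, with a step of an at least 1.6-fold lower number from compound 2 to compound 3 (0.22 log units; that floor lies within the scatter) that reaches beyond the scatter. Compound 3 is estimated at 60 ug/mL, within 15 ug/mL to 200 ug/mL.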

Compound 3, solubility: > 100 ug/mL
Compound 3 was reported as a limit; the forecaster's own chance of this, stated with the estimate: 40%; at least 1.6-fold (0.22 log units) between middle value and limit.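

In this assay, compound 3 gives a limit, as do compound 1 and compound 2, so no step from either compound to compound 3 can be read: the limit of > 100 ug/mL in this assay, at which 3 of the 3 values shown sit.

The compounds shown leave open how far apart these three lie in this assay and whether hydrogen in place of piperazin-1-yl changes the read-out at all.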